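A hydroxyphenyl sulfonamide in place of a thiophene

This account rests on a few compounds, and the source may have more. Where it says the series, first, only, none or still open, it means among the compounds named here.

Measured compounds:
Compound 1, `Cc1ccc(S(=O)(=O)Nc2ccc(-c3nc4ccccc4o3)cc2)cc1`, reaches only a limit in this assay, > 100000 nM.
Compound 2, `O=S(=O)(Nc1ccc(-c2nc3ccccc3o2)cc1)c1cccs1`, gives 63000 nM.

Both compounds share one core and differ only in the ring attached to the sulfonyl sulfur. In an assay on cells for inhibition of HSP60/HSP10 (Homo sapiens), with a stated time of 60 min (a lower number here means a stronger inhibitor, a higher number a weaker inhibitor), compound 1 reaches only a limit, > 100000 nM, which is one end of the range the assay reports, (the limit of > 100000 nM in this assay, at which 1 of the 2 values shown sits). Compound 2 gives 63000 nM. Among the compounds with values here, the single step that connects them, an at least 1.5-fold lower number from compound 1 to compound 2 (0.20 log units; that floor lies within the scatter), is therefore a floor rather than a firm size. Within the data shown here, compound 2 thus stands as the only compound with an actual number; the other value is a limit.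

Compound 3, `O=S(=O)(Nc1ccc(-c2nc3ccccc3o2)cc1)c1ccc(O)cc1`, differs from compound 2 in that (4-hydroxyphenyl in place of thiophen-2-yl on a sulfonyl sulfur). Among the measured compounds shown here, no measured step adds or removes a hydroxyl group, and the only measured step, an at least 1.5-fold lower number from compound 1 to compound 2 (0.20 log units; that floor lies within the scatter), changes the ring itself, so it offers a weak guide at best. Without a firm step to build on, compound 3 is expected to stay close to compound 2, within the scatter, with a fair chance that the assay again returns only a limit. Compound 3 is therefore estimated at 80000 nM, with a range from 30000 nM to 200000 nM. This estimate for compound 3 corresponds to a step of a 1.3-fold higher number from compound 2 to compound 3 (0.10 log units; within the scatter).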

Compound 3, half-maximal inhibitory concentration: 78000 nM
Estimate against measurement, compound 3: 1.0-fold (0.01 log units) above, and the stated range covers the measured number.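

In this assay, putting 4-hydroxyphenyl in place of thiophen-2-yl on the sulfonyl sulfur exchanges a five-membered aromatic ring for a six-membered one and adds a hydrogen-bond donor, yet the result is a 1.2-fold higher number from compound 2 to compound 3 (0.09 log units; within the scatter), so the assay does not separate these two compounds. At this position, then, neither the change of ring nor the added donor shifts the number beyond the scatter. Hydroxy in place of methyl on an aromatic carbon gives an at least 1.2-fold lower number from compound 1 to compound 3 (0.10 log units; that floor lies within the scatter), but the true size of this step cannot be read because compound 1 reaches only a limit: the limit of > 100000 nM in this assay, at which 1 of the 3 values shown sits.

As far as these compounds go, whether any group at this position can move the number beyond the scatter remains open, as all three compounds carry a single aromatic ring on the sulfonyl sulfur, and how an amine or a carboxylic acid on that ring would read is unknown. A methoxy group in place of the hydroxy would test whether the hydroxyl hydrogen matters here, a question these compounds cannot answer.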